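The compounds below may be only part of what the source reports. "The series", "measured", "known", "first", "only" and "open" are said of these compounds alone.

Measured so far:
compound 1, `O=C1CN(C2CCCC2)c2nc(Nc3ccc(N4CCCCC4)cn3)ncc2N1`: > 30000 nM, a limit of the assay
compound 2, `CN1CCN(c2ccc(Nc3ncc4c(n3)N(C3CCCC3)CC(=O)N4C)nc2)CC1`: 23700 nM

Among the compounds with values here, in a functional assay on MDA-MB-231 cells (Homo sapiens) for inhibition, read by MTT assay, with a stated time of 48 h (a higher number here means a weaker inhibitor, a lower number a stronger inhibitor), compound 2 gives 23700 nM, the only number the series offers so far. Compound 1 reaches only a limit in this assay, > 30000 nM. the limit of > 30000 nM in this assay, at which 1 of the 2 values shown sits, sets the edge of what this assay resolves, so compound 2 stands as the weak but measurable member of the pair.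

Compound 3, `CN1C(=O)CN(C2CCCC2)c2nc(Nc3ccc(N4CCCCC4)cn3)ncc21`, differs from compound 2 in one place: piperidin-1-yl in place of 4-methylpiperazin-1-yl on an aromatic carbon. Within the data shown here, no step between measured compounds is on record; compound 1 and compound 2 differ in two places, and their values show one limit and one weak number, which gives no separate read on this single change.

Compound 1 also carries piperidin-1-yl and sits at the limit. Compound 3 is therefore expected to fall at 35000 nM, within a range of 15000 nM to 90000 nM. The expected step is a 1.5-fold higher number from compound 2 to compound 3 (0.17 log units; within the scatter), toward weaker inhibition, with a fair chance that this assay returns only a limit.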

Compound 3, half-maximal inhibitory concentration: 29300 nM
Compound 3: the middle estimate sits 1.2-fold (0.08 log units) above what was measured; the range from low to high includes it.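

In this assay, this position now has a direct read for a single change, which the earlier pair could not give: the exchange of 4-methylpiperazin-1-yl for piperidin-1-yl on the aromatic carbon gives a 1.2-fold higher number from compound 2 to compound 3 (0.09 log units; within the scatter), so the loss of one ring nitrogen and one hydrogen-bond acceptor leaves compound 2 and compound 3 unseparated. On the amide-type nitrogen in the ring, methyl in place of hydrogen gives an at least 1.0-fold lower number from compound 1 to compound 3 (0.01 log units; that floor lies within the scatter), so this second single change also shows no separation beyond the scatter. The value of compound 1 is a limit of the assay and not a number, so this step is a floor only: the limit of > 30000 nM in this assay, at which 1 of the 3 values shown sits.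

Neither ring group on this aromatic carbon gives a basis for ranking, and the compounds shown say nothing about whether morpholin-4-yl, a primary amine or a carboxylic acid there would separate from compound 2 and compound 3. From the compounds shown here alone, on the amide-type nitrogen, the size of the methyl step remains open, as does the outcome with a longer chain such as propyl in place of methyl.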